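Swapping a Side Group, Expecting Only a Modest Shift

The source may hold more compounds than are shown below. What is called first, only, known or untested is meant among the compounds shown, and "the series" means these compounds.

Compound 1 `COc1cc(OCc2cccc(COc3ccccc3)c2)c2cc(-c3cn4nc(OC)sc4n3)oc2c1`: 64%
Compound 2 `CS(=O)(=O)c1nn2cc(-c3cc4ccccc4o3)nc2s1`: "not determined" (no result reported)

For the measured compounds named here, compound 1 is the only compound with a number in an ADME assay on microsomes from liver (Rattus norvegicus) for metabolic stability, with a stated time of 10 min; a higher number here means that more of the compound is left, a lower number that less of the compound is left; compound 2 has no result there. Compound 3 `COc1cc(OCc2cccc(Sc3ccccc3)c2)c2cc(-c3cn4nc(OC)sc4n3)oc2c1` differs from compound 1 in one place: phenylsulfanyl in place of phenoxymethyl on an aromatic carbon. Going by the values given here, no measured pair shows what such a change does, so the expected step in this assay is modest, most likely within the usual scatter, with some room for a decrease. Compound 3 is estimated to give 55% (30% to 80%). This estimate means a number 9 percentage points lower from compound 1 to compound 3 (within the scatter).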

Compound 3, percent of the compound remaining: 45%
Estimate against measurement, compound 3: 10 percentage points above; low and high end bracket the measured number.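

On an aromatic carbon meta to a large group, the side group matters in this assay: phenylsulfanyl in place of phenoxymethyl gives a number 19 percentage points lower from compound 1 to compound 3 (beyond the scatter) and so leaves less of the compound intact. For the compounds shown here, this is the first measured pair at this position, and it shows that a swap between two groups of similar size, each carrying one benzene ring, can register in this test. Nothing measured here explains the step.

The compounds shown leave open whether the sulfur or the lost carbon accounts for the step. From the compounds shown here alone, how phenoxy, with oxygen in place of the sulfur, or an amine would behave at this position also stays open.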